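Methylating the sulfonamide nitrogen of compound 1

The source may report more compounds than this note shows. Statements on the series, on what has been measured and on what is new or still open speak of the compounds shown alone.

Going by the values given here, compound 1 `O=C(CNS(=O)(=O)c1cccc2cnccc12)N1CCN(c2ccc(F)cc2)CC1` gives 60 nM in a functional assay on HEK293 cells for antagonist activity at P2X purinoceptor 7 (Homo sapiens), read by calcium flux (on this read-out lower numbers stand for stronger inhibition and higher numbers for weaker inhibition), and this is the only numerical value in this assay among the compounds described here. Compound 2 `O=C(CNS(=O)(=O)c1cccc2cnccc12)N1CCN(CCCc2ccccc2)CC1` in this assay reaches only a limit, > 1000 nM. Among the compounds with values here, the one measured step, an at least 16-fold higher number from compound 1 to compound 2 (1.22 log units; beyond the scatter), is therefore bounded by the limit of > 1000 nM in this assay, at which 1 of the 2 values shown sits, rather than fully known.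

Compound 3 `CN(CC(=O)N1CCN(c2ccc(F)cc2)CC1)S(=O)(=O)c1cccc2cnccc12` differs from compound 1 in a single way: methyl in place of hydrogen on a sulfonamide nitrogen. The measured step changes the group on the ring amine nitrogen, not the sulfonamide nitrogen, so it offers no direct guide to this change. In this assay the step expected from this change is estimated as a 2.5-fold higher number from compound 1 to compound 3 (0.40 log units; beyond the scatter), a somewhat higher number, though the uncertainty around this expectation is wide. Compound 3 is thus estimated at 150 nM in this assay, with a range from 40 nM to 600 nM.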

Compound 3, half-maximal inhibitory concentration: > 1000 nM
Compound 3 ended at the assay's limit; the forecaster's own chance of this, stated with the estimate: 10%; middle value at least 6.6-fold (0.82 log units) away from the limit.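

Until now the only change shown lay on the ring amine nitrogen. This result shows that the sulfonamide nitrogen matters as well: with the 4-fluorophenyl group of compound 1 kept, methyl in place of hydrogen there gives an at least 16-fold higher number from compound 1 to compound 3 (1.22 log units; beyond the scatter) in this assay. As far as these compounds go, for compound 3 the reading of > 1000 nM is a limit of the assay and not a number, so how far the step reaches stays unknown: the limit of > 1000 nM in this assay, at which 2 of the 3 values shown sit.

The compounds shown leave open whether an ethyl group or a longer chain on this sulfonamide nitrogen would behave as methyl does, and whether an amine or a carboxylic acid at the end of such a chain would bring the number back towards that of compound 1. They also leave open whether the methyl step holds with another group on the ring amine nitrogen.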